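Tetrazole for carboxylate one bond further out

The compounds below may be only part of what the source reports. "The series", "measured", "known", "first", "only" and "open" are said of these compounds alone.

Compound 1 `CCCc1c(COc2ccc(C(=O)CCc3nnn[nH]3)cc2)ccc(C(C)=O)c1O`: 10.1 mg/kg
Compound 2 `CCCc1c(COc2ccc(C(=O)CCCC(=O)O)cc2)ccc(C(C)=O)c1O`: 9.5 mg/kg

In an in vivo functional assay on the whole organism (Rattus norvegicus) with cysteinyl leukotriene receptor (Homo sapiens) as the target (a lower number here means that less compound is needed, a higher number that more compound is needed for the effect), compound 1 gives 10.1 mg/kg and compound 2 gives 9.5 mg/kg; the two numbers sit within the scatter of each other, as the step of a 1.1-fold lower number from compound 1 to compound 2 (0.03 log units; within the scatter) shows. Compound 3 `CCCc1c(COc2ccc(C(=O)CCCc3nnn[nH]3)cc2)ccc(C(C)=O)c1O` differs from compound 2 by 1H-tetrazol-5-yl in place of carboxy on a saturated chain carbon, three bonds along the chain from a carbonyl carbon. For the measured compounds named here, the one measured step that bears on this exchange is a 1.1-fold lower number from compound 1 to compound 2 (0.03 log units; within the scatter), the same swap one bond nearer the carbonyl, and it moved nothing beyond the scatter. No change beyond the scatter is therefore expected for compound 3, estimated at 9.5 mg/kg with a range of 4.5 mg/kg to 20 mg/kg. The expected step is no change at the digits printed from compound 2 to compound 3 (within the scatter).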

Compound 3, dose for half-maximal effect: 7.2 mg/kg
Compound 3: middle estimate off by 1.3-fold (0.12 log units), on the high side, and the stated range covers the measured number.
By their numbers in this assay, from the lowest: compounds 3, 2 and 1 (each within the scatter of the next).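

In this assay, 1H-tetrazol-5-yl in place of carboxy three bonds along the chain from a carbonyl carbon gives a 1.3-fold lower number from compound 2 to compound 3 (0.12 log units; within the scatter), so this exchange now stays within the scatter at a second chain length as well. Extending the tetrazole-bearing chain, with (1H-tetrazol-5-yl)methyl in place of 1H-tetrazol-5-yl, gives a 1.4-fold lower number from compound 1 to compound 3 (0.15 log units; within the scatter), which also stays within the scatter. Nothing shown here explains why these numbers stay so close. Still open, from the compounds shown here alone, is whether a longer chain ending in 1H-tetrazol-5-yl or carboxy would stay within the scatter, and whether an acylsulfonamide or a primary amide at the chain end would do the same.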